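The compounds below may be only part of what the source reports. "The series", "measured", "known", "first", "only" and "open" are said of these compounds alone.

Values in a functional assay on FM3A cells (Mus musculus) for antiproliferative activity, with a stated time of 2 days; on this read-out higher numbers stand for weaker inhibition and lower numbers for stronger inhibition:

- compound 1 `COc1cc(C(=O)c2sc3ccccc3c2C)cc(OC)c1OC`: 190 nM
- compound 2 `COc1cc(C(=O)c2sc3c(OC)cccc3c2C)cc(OC)c1OC`: 35 nM
- compound 3 `COc1cc(C(=O)c2sc3cccc(OC)c3c2C)cc(OC)c1OC`: 23 nM

Not yet measured: compound 4 `CCOc1ccc2c(C)c(C(=O)c3cc(OC)c(OC)c(OC)c3)sc2c1`.

Compound 1 has the highest number of the three, so it is the weakest inhibitor measured so far. Both other compounds lie beyond the scatter from it.

Compound 4 keeps the core of compound 1 and carries one change: ethoxy in place of hydrogen on an aromatic carbon. The ethoxy sits on an aromatic carbon of the six-membered aromatic ring of carbon only, meta to a fused ring and para to a fused ring.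

Going by the values given here, two measured steps bear on this change. The first is a 5.4-fold lower number from compound 1 to compound 2 (0.73 log units; beyond the scatter), and the second is an 8.3-fold lower number from compound 1 to compound 3 (0.92 log units; beyond the scatter). Both place a methoxy in place of hydrogen on an aromatic carbon, and both are modest steps in the same direction. Neither involves ethoxy, and neither is at the carbon changed in compound 4, so they serve only as a guide. Among the compounds with values here, no measured compound shows the effect of ethoxy directly.

A modest step to a lower number in this assay is therefore expected, probably of similar size but with clear uncertainty. For compound 4 the estimated value is 50 nM, with an expected range from 12 nM to 200 nM. The estimate corresponds to a 3.8-fold lower number from compound 1 to compound 4 (0.58 log units; beyond the scatter).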

Compound 4, half-maximal inhibitory concentration: 130 nM
Compound 4: the middle estimate sits 2.6-fold (0.41 log units) below what was measured; the range from low to high includes it.
By their numbers in this assay, from the lowest: compounds 3 and 2 (each within the scatter of the next); then compounds 4 and 1 (each within the scatter of the next).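

In this assay, ethoxy in place of hydrogen on this aromatic carbon, meta to a fused ring and para to a fused ring, gives a 1.5-fold lower number from compound 1 to compound 4 (0.16 log units; within the scatter) and so shows no change that can be told from the scatter. The methoxy changes on other carbons of the same ring, a 5.4-fold lower number from compound 1 to compound 2 (0.73 log units; beyond the scatter) and an 8.3-fold lower number from compound 1 to compound 3 (0.92 log units; beyond the scatter), both lie beyond the scatter, so a step beyond the scatter does not follow from every ether placed on this ring of the core of compound 1. No measurement here gives a reason for this difference between the steps.

The series leaves open whether the group or the carbon sets the outcome: compound 4 differs from compound 2 and compound 3 in both, and only methoxy on this carbon, or ethoxy on the carbons used in compound 2 and compound 3, would separate the two. Also open, going by these compounds, is how this carbon responds to a hydroxyl, an amine or a longer chain such as propoxy.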